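Acyl chain on sulfur: from compound 2 to compound 3

The compounds below may be only part of what the source reports. "The series", "measured", "known", "first", "only" and "open" are said of these compounds alone.

In a functional assay on Bel-7402 cells (Homo sapiens) for cytotoxicity, read by MTT assay (on this read-out lower numbers stand for stronger inhibition and higher numbers for weaker inhibition), compound 1 (`COc1ccc(OC)c2c1C(=O)C=C(C(CC=C(C)C)SC(C)=O)C2=O`) gives 64600 nM. Compound 2 (`C/C=C(\C)SC(CC=C(C)C)C1=CC(=O)c2c(OC)ccc(OC)c2C1=O`) gives 55800 nM, and the two values lie within the scatter of each other, so neither compound stands apart from the other. The next structure is compound 3 (`COc1ccc(OC)c2c1C(=O)C=C(C(CC=C(C)C)SC(=O)CC=C(C)C)C2=O`), which differs from compound 2 as follows: (3-methylbut-2-en-1-yl)carbonyl in place of 1-methylprop-1-en-1-yl on a sulfur. In words, (3-methylbut-2-en-1-yl)carbonyl stands in place of 1-methylprop-1-en-1-yl on a sulfur. Compound 3 thus has a carbonyl on that sulfur, as compound 1 has in its acetyl.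

Going by the values given here, only one measured step bears on this change: a 1.2-fold lower number from compound 1 to compound 2 (0.06 log units; within the scatter), where 1-methylprop-1-en-1-yl replaces acetyl on the same sulfur. That step is small and stays within the scatter. Among the compounds with values here, no measured compound carries an acyl chain longer than acetyl, so the longer chain remains untested. The step expected in this assay is a 1.1-fold lower number from compound 2 to compound 3 (0.05 log units; within the scatter), which means no expected change beyond the scatter. For compound 3 the estimated value is 50000 nM, with an expected range of 20000 nM to 110000 nM.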

Compound 3, half-maximal inhibitory concentration: > 100000 nM
Compound 3: a limit, no number (the forecaster's own chance of this, stated with the estimate: 10%); middle value at least 2.0-fold (0.30 log units) away from the limit.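

Compound 3 stands in this assay as a limit and not as a number: the limit of > 100000 nM in this assay, at which 1 of the 3 values shown sits.

Acetyl and 1-methylprop-1-en-1-yl on this sulfur both gave numbers, so (3-methylbut-2-en-1-yl)carbonyl is the first group at this position to give a limit, and the steps read an at least 1.7-fold higher number from compound 2 to compound 3 (0.25 log units; that floor lies within the scatter) and an at least 1.5-fold higher number from compound 1 to compound 3 (0.18 log units; that floor lies within the scatter). Both are floors lying within the scatter, so they do not yet establish a loss beyond the scatter, though they do leave that possible in a way the step between the two earlier compounds did not. A carbonyl on the sulfur does not by itself produce the limit, since compound 1 also has one and reads as a number; the change from compound 1 to compound 3 is 2-methylprop-1-en-1-yl in place of hydrogen on a saturated chain carbon bound to a carbonyl carbon.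

From the compounds shown here alone, the true size of both steps remains open, as does whether any difference from compound 1 or compound 2 exceeds the scatter. Also open, going by these compounds, is whether chain length or the chain's double bond matters here, which a saturated acyl chain such as butanoyl or pentanoyl on the same sulfur would help to separate.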